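Removing the imidazolyl group from a guanidine-acyl sulfone inhibitor

The compounds below may be only part of what the source reports. "The series", "measured", "known", "first", "only" and "open" are said of these compounds alone.

Compound 1: `Cc1cc(Sc2ccc(Cl)cc2)c(S(C)(=O)=O)cc1C(=O)N=C(N)N` — 19 nM
Compound 2: `Cc1cn(-c2cc(C)c(C(=O)N=C(N)N)cc2S(C)(=O)=O)cn1` — 28 nM

In a functional assay for inhibition of sodium/hydrogen exchanger (Oryctolagus cuniculus) (on this read-out higher numbers stand for weaker inhibition and lower numbers for stronger inhibition), compound 1 gives 19 nM, and compound 2 gives 28 nM. Compound 2 has the highest of the two numbers shown, but the step of a 1.5-fold higher number from compound 1 to compound 2 (0.17 log units; within the scatter) is within the scatter, so the two compounds cannot be ordered on this read-out.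

Compound 3, `Cc1ccc(S(C)(=O)=O)cc1C(=O)N=C(N)N`, differs from compound 2 by hydrogen in place of 4-methyl-1H-imidazol-1-yl on an aromatic carbon. Among the compounds with values here, the only measured step, a 1.5-fold higher number from compound 1 to compound 2 (0.17 log units; within the scatter), swaps one group for another at this position and bears on the new step merely indirectly: it shows that two quite different groups there give indistinguishable numbers, but it says nothing about leaving the position bare. Lacking a direct precedent, the direction of the step cannot be read from the two measured compounds.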

Compound 3, half-maximal inhibitory concentration: 150 nM
Beside the measured number, compound 3's estimate is 1.5-fold (0.18 log units) below it; the range from low to high includes it.
By their numbers in this assay, from the lowest: compounds 1 and 2 (each within the scatter of the next); then compound 3.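

In this assay, the position turns out not to be indifferent: replacing 4-methyl-1H-imidazol-1-yl with hydrogen gives a 5.4-fold higher number from compound 2 to compound 3 (0.73 log units; beyond the scatter), and replacing (4-chlorophenyl)sulfanyl with hydrogen gives a 7.9-fold higher number from compound 1 to compound 3 (0.90 log units; beyond the scatter). Compound 1 and compound 2 cannot be ordered, yet each inhibits more strongly than compound 3, so two quite different groups both give a lower number than the bare aromatic carbon. No measured evidence is available to explain this difference.

The compounds shown leave open how much of a group this position needs, and whether an amine or a single chlorine atom there would give a number like those of compound 1 and compound 2 or like that of compound 3. They also do not show which part of either group matters, a question that a plain phenylsulfanyl group would begin to address.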